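Ring contraction on the amide nitrogen of compound 2

A few compounds are considered here, and "the series" means these few. Any claim that something is new, unique, unknown or untested is made for them only; others in the source may bear on it.

Compound 2 `CCN(CC)S(=O)(=O)c1ccc(S(=O)(=O)N2CCC[C@@H](C(=O)NC3CCOCC3)C2)cc1` is the weaker of the two measured compounds: in a functional assay on BXPC-3 cells (Homo sapiens) for inhibition, read by MTT assay, with a stated time of 7 days (on this read-out higher numbers stand for weaker inhibition and lower numbers for stronger inhibition), compound 2 gives 8570 nM, whereas compound 1 `CCN(CC)S(=O)(=O)c1ccc(S(=O)(=O)N2CCC[C@@H](C(=O)N3CCC(OC)CC3)C2)cc1` gives 1420 nM. The step of a 6.0-fold higher number from compound 1 to compound 2 (0.78 log units; beyond the scatter) is the only measured one, and it exchanges one amide substituent for another rather than altering ring size. Compound 3 `CCN(CC)S(=O)(=O)c1ccc(S(=O)(=O)N2CCC[C@@H](C(=O)N[C@H]3CCOC3)C2)cc1` carries the change (oxolan-3-yl in place of oxan-4-yl on an amide-type nitrogen). Within the data shown here, no measured step shrinks a ring on this nitrogen, so the step from compound 1 to compound 2 bears on it only loosely, as a sign that the amide substituent can shift the number by a modest amount. Compound 3 is therefore expected to give a number near that of compound 2, with a step of a 1.1-fold lower number from compound 2 to compound 3 (0.03 log units; within the scatter) that is not expected to reach clearly beyond the scatter. The estimate for compound 3 in this assay is 8000 nM, within a range from 3000 nM to 25000 nM.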

Compound 3, half-maximal inhibitory concentration: 5270 nM
Estimate against measurement, compound 3: 1.5-fold (0.18 log units) above, within the range that was stated.
By their numbers in this assay, from the lowest: compound 1; then compounds 3 and 2 (each within the scatter of the next).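

In this assay the ring on the amide-type nitrogen goes from six-membered to five-membered with a 1.6-fold lower number from compound 2 to compound 3 (0.21 log units; within the scatter) as the result, a step within the scatter, so oxolan-3-yl in place of oxan-4-yl does not separate these two compounds. Compound 1 now stands apart from both, with a 3.7-fold higher number from compound 1 to compound 3 (0.57 log units; beyond the scatter) and a 6.0-fold higher number from compound 1 to compound 2 (0.78 log units; beyond the scatter) each beyond the scatter, so among these three compounds the 4-methoxypiperidin-1-yl on the carbonyl carbon, and not the ring size on the amide-type nitrogen, marks the clear difference. Nothing measured here accounts for either result.

As far as these compounds go, the opposite stereoisomer of oxolan-3-yl remains open, as does whether an oxetan-3-yl or a pyrrolidin-3-yl ring on this nitrogen would stay within the scatter of compound 2. From the compounds shown here alone, it is also open whether a plain piperidin-1-yl on the carbonyl carbon would keep the number of compound 1.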